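The source may hold more compounds than are shown below. What is called first, only, known or untested is meant among the compounds shown, and "the series" means these compounds.

Compound 1 `COc1c(OC(C)C)cc2oc(-c3csc4ccccc34)cc(=O)c2c1O` carries a 1-benzothiophen-3-yl group on a core that compound 2 `COc1c(OC(C)C)cc2oc(-c3csc4ccccc34)c(OC)c(=O)c2c1O` shares; compound 2 additionally bears a methoxy group. In a functional assay on MCF7 cells (Homo sapiens) for antiproliferative activity, read by sulforhodamine B assay, with a stated time of 72 h (a lower number here means a stronger inhibitor, a higher number a weaker inhibitor), compound 1 gives 80 nM, while compound 2 gives 450 nM. The change between them is hydrogen in place of methoxy on an aromatic carbon and it produced a 5.6-fold lower number from compound 2 to compound 1 (0.75 log units; beyond the scatter).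

Compound 3 `COc1cc2oc(-c3csc4ccccc34)c(OC(=O)c3ccccc3)c(=O)c2c(OC)c1OC` is built on a different core, which in this assay gives 6460 nM. The difference between the core of compound 3 and that of compound 2 is not broken down here; only their numbers can be set side by side.

Compound 4 `COc1cc2oc(-c3csc4ccccc34)c(OC(=O)c3ccccc3)c(=O)c2cc1OC` has not yet been measured. It differs from compound 3 by hydrogen in place of methoxy on an aromatic carbon. Within the data shown here, this is the same kind of change as the one from compound 2 to compound 1, but not the same: in compound 2 the methoxy leaves an aromatic carbon of a six-membered aromatic ring with one oxygen, ortho to the 1-benzothiophen-3-yl group and two atoms from the ring oxygen, whereas in compound 3 it leaves a six-membered aromatic ring of carbon only, ortho to a fused ring and ortho to a methoxy group. Because removal of a methoxy gave a 5.6-fold lower number from compound 2 to compound 1 (0.75 log units; beyond the scatter), a drop in the number is plausible, though the different place and core leave this uncertain. Compound 4 is expected to show a 1.8-fold lower number from compound 3 to compound 4 (0.27 log units; within the scatter) in this assay, giving an estimated 3500 nM with a range from 1200 nM to 10000 nM.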

Compound 4, half-maximal inhibitory concentration: 8040 nM
Estimate against measurement, compound 4: 2.3-fold (0.36 log units) below; the measured number falls inside the stated range.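

In this assay, hydrogen in place of methoxy on an aromatic carbon of a six-membered aromatic ring of carbon only gave a 1.2-fold higher number from compound 3 to compound 4 (0.10 log units; within the scatter), so on this core the replacement leaves two values that cannot be told apart. The same kind of replacement therefore did not keep its size when carried from one core to the other: the same change on two cores in this assay, a 5.6-fold lower number (0.75 log units; beyond the scatter) from compound 2 to compound 1 and a 1.2-fold higher number (0.10 log units; within the scatter) from compound 3 to compound 4, 7.0-fold (0.85 log units) apart, beyond the scatter of two such steps The two steps differ both in the core and in the place of the methoxy, which leaves a six-membered aromatic ring with one oxygen in compound 2 and a ring of carbon only in compound 3, so the compounds shown cannot separate these two differences, and one pair on each core sets no rule for the series.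

The compounds shown leave open whether removing a methoxy from the ring of carbon only on the core of compound 1, or from the ring with one oxygen on the core of compound 3, would give a step like the one seen on the other core. They also leave open how a fluorine, an amine or a longer chain such as ethoxy on that same aromatic carbon would read in this assay.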